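The compounds below may be only part of what the source reports. "The series", "measured", "known", "first", "only" and "open" are said of these compounds alone.

Measured compounds:
compound 1 `CC1(C)C=C(n2ccccc2=O)c2cc(C(=O)c3cccs3)ccc2O1` — 5.84
compound 2 `CC1(C)C=C(n2ccccc2=O)c2cc(C(=O)c3ccc([N+](=O)[O-])cc3)ccc2O1` — 6.09
compound 3 `CC1(C)C=C(n2ccccc2=O)c2cc(OC(=O)Nc3ccccc3C(F)(F)F)ccc2O1` — 5.19

In a functional assay (trachea) with Rattus norvegicus as the target (on this read-out lower numbers stand for lower potency and higher numbers for higher potency (the scale is a negative logarithm)), compound 1 gives 5.84, the second highest of the three numbers. Compound 2 sits nearest, the change being a number 0.25 log units higher from compound 1 to compound 2 (within the scatter). Within the data shown here, compound 3 gives 5.19, which lies beyond the scatter from compound 1; no single-place step links these two compounds, so the two values alone are what is known.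

Compound 4 `CC1(C)C=C(n2ccccc2=O)c2cc(C#N)ccc2O1` has not yet been measured. It differs from compound 1 as follows: cyano in place of (thiophen-2-yl)carbonyl on an aromatic carbon. Among the measured compounds shown here, no measured step touches this change. For the measured compounds named here, the one measured step, from compound 1 to compound 2, exchanges one aryl for another on the carbonyl carbon and stays within the scatter, and compound 3 shows that a different group on the same aromatic carbon can go with a lower number. On that basis a modest fall in this assay is expected for compound 4, and the step is estimated at a number 0.44 log units lower from compound 1 to compound 4 (beyond the scatter). The value for compound 4 is estimated at 5.4, with an expected range from 4.8 to 6.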

Compound 4, logarithm of the reciprocal of the active concentration, log(1/C): 7.1
Estimate against measurement, compound 4: 1.70 log units below; measured number outside the range, above it.
By their numbers in this assay, from the lowest: compound 3; then compounds 1 and 2 (each within the scatter of the next); then compound 4.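

In this assay, cyano in place of (thiophen-2-yl)carbonyl on this aromatic carbon gives a large step, a number 1.26 log units higher from compound 1 to compound 4 (beyond the scatter), whereas the exchange of one aryl for another on the carbonyl carbon stayed at a number 0.25 log units higher from compound 1 to compound 2 (within the scatter). This position therefore responds far more to replacing the whole group than to changing the aryl on the carbonyl carbon, and neither the carbonyl nor the five-membered aromatic ring of compound 1 is required for a high number: the entering group has 2 heavy atoms and no ring. No measurement in hand bears on the reason for this rise.

Open, as far as these compounds go, is whether the rise belongs to cyano itself or simply to the removal of the larger group; a chlorine, a carboxylic acid or a primary amide on this aromatic carbon would help to separate the two. Also open, from the compounds shown here alone, is whether cyano keeps this number when the two methyl groups of the shared core give way to a longer chain.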